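Aryl-methyl triazolyl ureas: two measured, one to estimate

The source may hold more compounds than are shown below. What is called first, only, known or untested is meant among the compounds shown, and "the series" means these compounds.

Measured compounds:
compound 1 `COc1ccc(CN(C(=O)Nc2ccc(C#N)cc2)n2cnnc2)cc1OC` — > 50000 nM
compound 2 `COc1ccc(CN(C(=O)Nc2ccc(Cl)c(C(F)(F)F)c2)n2cnnc2)cc1OC` — 29300 nM

In a functional assay on A549 cells (Homo sapiens) for cytotoxicity, read by MTT assay, with a stated time of 48 h (a higher number here means a weaker inhibitor, a lower number a stronger inhibitor), compound 2 gives 29300 nM. Among the compounds with values here, this is the only number reported in this assay; the other entry is a limit, not a number. For compound 1 the result in this assay is the limit > 50000 nM. The evidence on the series is therefore thin: the limit of > 50000 nM in this assay, at which 1 of the 2 values shown sits, leaving compound 2 as the single quantified point, and it is a weak inhibitor.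

Compound 3 `Cc1ccsc1CN(C(=O)Nc1ccc(Cl)c(C(F)(F)F)c1)n1cnnc1` is not yet measured in this assay. It differs from compound 2 in one place: 3-methylthiophen-2-yl in place of 3,4-dimethoxyphenyl on a saturated chain carbon bound to an amide-type nitrogen

Within the data shown here, no step between measured compounds is available, so the size and direction of the change from compound 2 to compound 3 cannot be read from the data. With only a weak inhibitor as the starting point, the expectation is a step within the scatter, or little beyond it, in either direction; the estimated step from compound 2 to compound 3 is a 1.0-fold higher number from compound 2 to compound 3 (0.01 log units; within the scatter). Compound 3 is expected to give 30000 nM in this assay, with a range from 10000 nM to 90000 nM.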

Compound 3, half-maximal inhibitory concentration: 26200 nM
For compound 3 the middle estimate is 1.1-fold (0.06 log units) above the measured one, and the stated range covers the measured number.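

In this assay, the series now has its first readable step at this position, a 1.1-fold lower number from compound 2 to compound 3 (0.05 log units; within the scatter), so the two values stand within the scatter of each other. On a saturated chain carbon bound to an amide-type nitrogen, a five-membered aromatic ring with 1 hetero atom and 6 heavy atoms can therefore stand in place of a six-membered aromatic ring of carbon only with 10 heavy atoms, and the 2 oxygen atoms of 3,4-dimethoxyphenyl are not needed to hold the read-out at this level. This is a comparison among weak inhibitors only, as compound 2 and compound 3 both remain weak and the rest of the series offers no stronger reference point: the limit of > 50000 nM in this assay, at which 1 of the 3 values shown sits.

From the compounds shown here alone, whether an amine or a carboxylic acid on the ring at this place, or a longer chain in place of the saturated chain carbon, would give a step beyond the scatter in this assay remains open. Also open, going by these compounds, is whether 3-methylthiophen-2-yl would behave the same way with the nitrile-bearing urea of compound 1, whose entry is a limit and not a number.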